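This account rests on a few compounds, and the source may have more. Where it says the series, first, only, none or still open, it means among the compounds named here.

In an ADME assay (liver, Mus musculus) for metabolic stability, using microsomes (a lower number here means that the compound disappears faster, a higher number that the compound lasts longer), compound 1 `CCCc1nc2ccccn2c1C(=O)NCc1ccc(-c2ccccc2)cc1` gives 0.145 h and compound 2 `CCc1nc2cc(Cl)ccn2c1C(=O)NCc1ccc(-c2ccc(C)cc2)cc1` gives 0.385 h while compound 3 `CCc1nc2cc(Cl)ccn2c1C(=O)NCc1ccc(-c2ccc[nH]2)cc1` gives 0.18 h as its half-life. Compound 3 thus lies within the scatter of compound 1 and under compound 2. Still unmeasured is compound 4 `CCc1nc2cc(Cl)ccn2c1C(=O)NCc1ccc(N2CCCCCC2)cc1` which carries azepan-1-yl in place of 1H-pyrrol-2-yl on an aromatic carbon. For the measured compounds named here, only one measured step bears on this place, a modest one (a 2.1-fold lower number from compound 2 to compound 3 (0.33 log units; beyond the scatter)) with 1H-pyrrol-2-yl in place of 4-methylphenyl. Going by the values given here, no measured compound carries a non-aromatic ring there, so that step gives no direction, and no shift beyond the scatter is expected in this assay for this change. The estimated step reads (a 1.1-fold lower number from compound 3 to compound 4 (0.02 log units; within the scatter)). Compound 4 is estimated at 0.17 h with an expected range from 0.07 h to 0.42 h for its half-life.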

Compound 4, half-life: 0.0317 h
Estimate against measurement, compound 4: 5.4-fold (0.73 log units) above, outside the stated range (below it).
By their numbers in this assay, from the lowest: compound 4; then compounds 1 and 3 (each within the scatter of the next); then compound 2.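

In this assay, azepan-1-yl on this aromatic carbon, para to a large group, gives a 5.7-fold lower number from compound 3 to compound 4 (0.75 log units; beyond the scatter) and a 12-fold lower number from compound 2 to compound 4 (1.08 log units; beyond the scatter) as well. Among the three groups compared at this place, the seven-membered non-aromatic ring thus stands lowest, under both aromatic rings. Nothing measured here accounts for this drop. On these data alone, whether ring size or the non-aromatic ring itself decides the outcome remains open. So does whether a piperidine, a morpholine or an open-chain dimethylamino group at this place would give a number as low.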